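Methyl Branching Repeated Across Two Saturated Cores

The source may report more compounds than this note shows. Statements on the series, on what has been measured and on what is new or still open speak of the compounds shown alone.

Compound 1 `CC(CN)C(CN)C(=O)O` opens the series. In an assay for inhibition of Ornithine decarboxylase (Rattus norvegicus) (on this read-out lower numbers stand for stronger inhibition and higher numbers for weaker inhibition), compound 1 gives 720000 nM. Compound 2 `CC(C)(CN)C(CN)C(=O)O` carries methyl in place of hydrogen on a saturated chain carbon bound to three saturated chain carbons. In this assay compound 2 reaches only a limit, > 11000000 nM. The step was an at least 15-fold higher number from compound 1 to compound 2 (1.18 log units; beyond the scatter). Compound 3 `CC(CN)C(C)(C)CN` differs from compound 2 by methyl in place of carboxy on a saturated chain carbon bound to two saturated chain carbons; how its core differs from that of compound 1 is not broken down here. In this assay compound 3 likewise reaches only a limit, > 10500000 nM. Hence a step that the two limits leave unreadable from compound 2 to compound 3. Compound 4 `CC(C)(CN)C(C)(C)CN` carries methyl in place of hydrogen on a saturated chain carbon bound to three saturated chain carbons, the same change as from compound 1 to compound 2. Since compound 3 already sits at the limit of > 10500000 nM in this assay, at which 1 of the 3 values shown sits, and the earlier methyl step was large, compound 4 is expected to stay beyond the limit, estimated at 60000000 nM. The expected step is a step that the limit leaves unreadable from compound 3 to compound 4, an estimate only, with a range from 10500000 nM to 500000000 nM.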

Compound 4, inhibition constant: > 11000000 nM
Compound 4 ended at the assay's limit (the forecaster's own chance of this, stated with the estimate: 95%); the middle value lies beyond the limit too.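

Compound 3 and compound 4 both reach only a limit in this assay, so no step can be read between them. The compounds shown leave open whether this methyl in place of hydrogen changes inhibition at all on the core of compound 3.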